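The source may report more compounds than this note shows. Statements on the series, on what has been measured and on what is new or still open speak of the compounds shown alone.

Measured compounds:
- compound 1, `N#C/C(=C\c1ccccc1OS(=O)(=O)c1ccc(Cl)cc1)C(=O)Nc1nnc(Cc2ccccc2)s1`: 25%
- compound 2, `N#C/C(=C\c1ccccc1OS(=O)(=O)c1ccc(F)cc1)C(=O)Nc1nnc(Cc2ccccc2)s1`: 6%
- compound 3, `N#C/C(=C\c1ccccc1OS(=O)(=O)c1ccc(Cl)cc1)C(=O)Nc1nnc(Cc2ccc(F)cc2)s1`: 6%

All three were run in an ADME assay on HEK-293T cells (Homo sapiens) for inhibition, read by CCK-8 assay, with a stated time of 48 h, tested at 20 uM; a higher number here means more inhibition of growth at the concentration tested, a lower number less inhibition of growth. Compound 1 gives 25% and stands highest of the three. From compound 1 to compound 2 the change is fluoro in place of chloro on an aromatic carbon; the step is a number 19 percentage points lower from compound 1 to compound 2 (beyond the scatter). From compound 1 to compound 3 the change is fluoro in place of hydrogen on an aromatic carbon, and the step is a number 19 percentage points lower from compound 1 to compound 3 (beyond the scatter). Compound 2 and compound 3 agree at the digits given, so no order between them is claimed.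

Compound 4, `N#C/C(=C\c1ccccc1OS(=O)(=O)c1ccc(F)cc1)C(=O)Nc1nnc(Cc2ccc(F)cc2)s1`, is not yet measured. It differs from compound 3 by fluoro in place of chloro on an aromatic carbon. This is the same change already seen from compound 1 to compound 2, and the surroundings of the place match word for word, so it is the same change on a different core; the two cores differ by fluoro in place of hydrogen on an aromatic carbon.

The earlier step of this change was a modest fall, but compound 3 already sits at the bottom of the measured range, so in this assay compound 4 is expected to show a number 4 percentage points lower from compound 3 to compound 4 (within the scatter), a smaller step than the first occurrence, resting on a number 19 percentage points lower from compound 1 to compound 2 (beyond the scatter) and on the low start of compound 3 at 6%. Compound 4 is estimated at 2%, within -10% to 15%.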

Compound 4, percent growth inhibition at one concentration: "not toxic" (no number reported)
Nothing numeric was reported for compound 4, so the estimate cannot be set against anything.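

In this assay, for the compounds shown here, compound 4 is recorded only in words, as not toxic, with no number, so no step from compound 3 to compound 4 can be read. Nothing shown bears on the reason for this result. The compounds shown leave open whether fluoro in place of chloro on the core of compound 3 repeats a number 19 percentage points lower from compound 1 to compound 2 (beyond the scatter).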